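This account rests on a few compounds, and the source may have more. Where it says the series, first, only, none or still open, it means among the compounds named here.

In an in vitro functional assay on HEK285-7 cells for antagonist activity at prostaglandin D2 receptor 2 (Homo sapiens), read by BRET and beta-arrestin recruitment (a lower number here means a stronger inhibitor, a higher number a weaker inhibitor), three compounds share one core and differ in the aryl groups attached to it. Compound 1 `O=C(O)Cc1sc(C(c2ccc(F)cc2)c2ccc(F)cc2)nc1-c1ccco1` gives 140 nM, compound 2 `O=C(O)Cc1sc(C(c2ccccc2)c2ccc(Cl)cc2)nc1-c1ccc(Cl)cc1` gives 75 nM, and compound 3 `O=C(O)Cc1sc(C(c2ccc(F)cc2)c2ccc(F)cc2)nc1-c1cn[nH]c1` gives 220 nM. Compound 2 has the lowest of these three numbers; its gap to compound 1 lies within the usual scatter, while its gap to compound 3 lies beyond it. Compound 4 `O=C(O)Cc1sc(C(c2ccccc2)c2ccc(F)cc2)nc1-c1ccc(Cl)cc1` differs from compound 2 by fluoro in place of chloro on an aromatic carbon. Going by the values given here, no measured step exchanges one halogen for another; the only single-point step, a 1.6-fold higher number from compound 1 to compound 3 (0.20 log units; within the scatter), concerns a different ring and stays within the scatter. Nothing measured here suggests a shift beyond the scatter, so the expected step is a 1.3-fold higher number from compound 2 to compound 4 (0.12 log units; within the scatter). Compound 4 is estimated at 100 nM in this assay, with a range from 45 nM to 220 nM.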

Compound 4, half-maximal inhibitory concentration: 36 nM
For compound 4 the middle estimate is 2.8-fold (0.44 log units) above the measured one; the measured number lies below the stated range.
By their numbers in this assay, from the lowest: compound 4; then compounds 2, 1 and 3 (each within the scatter of the next, the first and the last beyond it).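

In this assay, replacing 4-chlorophenyl with 4-fluorophenyl gives a 2.1-fold lower number from compound 2 to compound 4 (0.32 log units; beyond the scatter) and so shows that this place on the ring responds to a change of one halogen atom. The earlier compounds shown here could not show this, as none of them isolates a halogen exchange. The step is modest, and no measurement available here accounts for it. From the compounds shown here alone, what remains open is how a methyl or methoxy group would fare at this place, and whether the same exchange on the remaining 4-chlorophenyl group of compound 4 would move the number in the same direction.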